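Lengthening the Side Chain of Compound 3

The source may report more compounds than this note shows. Statements on the series, on what has been measured and on what is new or still open speak of the compounds shown alone.

Measured in a functional assay on DU-145 cells (Homo sapiens) for cytotoxicity, read by MTT assay; on this read-out higher numbers stand for weaker inhibition and lower numbers for stronger inhibition:
- compound 1 `CCCCC(O)CC(=O)O[C@H](CC=C(C)C)C1=CC(=O)c2c(O)ccc(O)c2C1=O`: 45300 nM
- compound 2 `CCC(CO[C@H](CC=C(C)C)C1=CC(=O)c2c(O)ccc(O)c2C1=O)OC(C)=O`: 25400 nM
- compound 3 `CC[C@@](C)(O)CC(=O)O[C@H](CC=C(C)C)C1=CC(=O)c2c(O)ccc(O)c2C1=O`: 12700 nM

Compound 3 gives 12700 nM. It stands clear of compound 1, with a 3.6-fold lower number from compound 1 to compound 3 (0.55 log units; beyond the scatter), but it cannot be separated from compound 2, with a 2.0-fold lower number from compound 2 to compound 3 (0.30 log units; within the scatter).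

The next structure is compound 4 `CCCCC(C)(O)CC(=O)O[C@H](CC=C(C)C)C1=CC(=O)c2c(O)ccc(O)c2C1=O`. Its change is 1-hydroxy-1-methylpentyl in place of 1-hydroxy-1-methylpropyl on a saturated chain carbon bound to a carbonyl carbon, which puts 1-hydroxy-1-methylpentyl in place of 1-hydroxy-1-methylpropyl on a saturated chain carbon bound to a carbonyl carbon.

For the measured compounds named here, only one measured step alters this same place, namely a 3.6-fold lower number from compound 1 to compound 3 (0.55 log units; beyond the scatter). That step swapped 1-hydroxypentyl for 1-hydroxy-1-methylpropyl, so compound 4 combines the pentyl chain of compound 1 with the methyl of compound 3. Part of that modest step may therefore be given back, though one step is thin evidence. The expected change is a 1.6-fold higher number from compound 3 to compound 4 (0.20 log units; within the scatter), a small move towards a higher number. In this assay the estimated value for compound 4 is 20000 nM, with an expected range of 8000 nM to 45000 nM.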

Compound 4, half-maximal inhibitory concentration: 76500 nM
Estimate against measurement, compound 4: 3.8-fold (0.58 log units) below; the whole stated range lies below it.
By their numbers in this assay, from the lowest: compounds 3, 2, 1 and 4 (each within the scatter of the next, the first and the last beyond it).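

In this assay, the longer chain is what separates compound 4 from compound 3 (a 6.0-fold higher number from compound 3 to compound 4 (0.78 log units; beyond the scatter)), so at this saturated chain carbon bound to a carbonyl carbon, 1-hydroxy-1-methylpentyl is clearly not interchangeable with 1-hydroxy-1-methylpropyl. The added methyl, by contrast, does not set compound 4 apart from compound 1, since that step stays within the scatter (a 1.7-fold higher number from compound 1 to compound 4 (0.23 log units; within the scatter)), while compound 4 does stand apart from the acetoxy compound (a 3.0-fold higher number from compound 2 to compound 4 (0.48 log units; beyond the scatter)). No measurement at hand accounts for this effect of chain length.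

On these data alone, whether a still longer chain, such as 1-hydroxy-1-methylheptyl, would continue this trend remains open. Also open, as far as these compounds go, is how a chain ending in an amine or a carboxylic acid would behave at this place.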